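A few compounds are considered here, and "the series" means these few. Any claim that something is new, unique, unknown or untested is made for them only; others in the source may bear on it.

Measured in an ADME assay on microsomes from liver (Homo sapiens) for metabolic stability, read by LC-MS, using NADPH, with a stated time of 10 min, tested at 10 uM; a higher number here means that the compound lasts longer, a lower number that the compound disappears faster:

Compound 1 `Nc1ncnc2c1c(Oc1cc(C(F)(F)F)ccn1)nn2[C@@H]1CCCC[C@H]1O`: > 2.41 h, a limit of the assay
Compound 2 `Nc1ncnc2c1c(Oc1cc(C(F)(F)F)ccn1)nn2[C@H]1CC[C@@H](N)CC1`: > 2.41 h, a limit of the assay
Compound 3 `Nc1ncnc2c1c(Oc1cc(C(F)(F)F)ccn1)nn2[C@H]1C[C@H](F)C1`: 2.03 h

Compound 3 is the only one of the three with an actual number. Compounds 1 and 2 both rest on (the limit of > 2.41 h in this assay, at which 2 of the 3 values shown sit), so the series offers little room for comparison.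

Compound 4 `Nc1ncnc2c1c(Oc1cc(C(F)(F)F)ccn1)nn2C1CCC1`, still unmeasured, departs from compound 3 by a single small change: hydrogen in place of fluoro on a saturated ring carbon. In words, hydrogen takes the place of fluoro on a saturated ring carbon, turning 3-fluorocyclobutyl into cyclobutyl.

Within the data shown here, no measured step makes this exchange. The nearest evidence is two steps that replace the whole group on an aromatic nitrogen: an at least 1.1-fold lower number from compound 1 to compound 3 (0.07 log units; that floor lies within the scatter) and an at least 1.1-fold lower number from compound 2 to compound 3 (0.07 log units; that floor lies within the scatter). Each of these is only a floor that lies within the scatter. Even these much larger replacements therefore show no readable shift, so no step beyond the scatter is expected in this assay, and no direction can be favoured.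

The estimated change is a 1.0-fold lower number from compound 3 to compound 4 (0.01 log units; within the scatter). For compound 4 the expected half-life is 2 h, with an estimated range from 1.1 h to 3.4 h.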

Compound 4, half-life: 1.02 h
The estimate for compound 4 lay 2.0-fold (0.29 log units) above the measured number; measured number outside the range, below it.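

At this position, on a saturated ring carbon of the four-membered ring, two ring bonds from the ring atom that bears a large group, hydrogen in place of fluoro gives a 2.0-fold lower number from compound 3 to compound 4 (0.30 log units; within the scatter) in this assay. Among these compounds, this is a step with a readable size, where the earlier steps to compound 3 gave only floors, and it does not pass beyond the scatter. The whole-group replacements on the aromatic nitrogen now do pass beyond it, with cyclobutyl in place of 4-aminocyclohexyl giving an at least 2.3-fold lower number from compound 2 to compound 4 (0.37 log units; beyond the scatter) and cyclobutyl in place of 2-hydroxycyclohexyl giving an at least 2.3-fold lower number from compound 1 to compound 4 (0.37 log units; beyond the scatter), so cyclobutyl stands apart from those two larger groups in a way that 3-fluorocyclobutyl did not.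

As far as these compounds go, the full size of these two steps stays open, since compounds 1 and 2 each carry a limit rather than a number: the limit of > 2.41 h in this assay, at which 2 of the 4 values shown sit. Also open is how a methyl, a methoxy or a nitrile on the same ring carbon would read against fluoro and hydrogen, and whether the same exchange would read alike on a larger saturated ring.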